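The compounds below may be only part of what the source reports. "The series", "measured", "known", "first", "only" and "open" are said of these compounds alone.

Three compounds have been measured in a functional assay on MCF7 cells (Homo sapiens) for cytotoxicity, read by MTT assay, with a stated time of 2 days, tested at 100 uM; a lower number here means a stronger effect, a higher number a weaker effect of the compound at the concentration tested:

compound 1, `CC(=O)c1cc(-c2ccc(F)cc2)cc2cc(-c3ccccc3)[nH]c12`, gives 36.4%;
compound 2, `COc1ccc(-c2cc(C(C)=O)c3[nH]c(-c4ccccc4)cc3c2)cc1`, gives 30.8%;
compound 3, `COc1ccc(-c2cc3cc(-c4ccc(F)cc4)cc(C(C)=O)c3[nH]2)cc1`, gives 47%.

Compound 1 and compound 2 differ by methoxy in place of fluoro on an aromatic carbon, and that change made a step of a number 5.6 percentage points lower from compound 1 to compound 2 (within the scatter). The core of compound 3 differs from the core of compound 1 by methoxy in place of hydrogen on an aromatic carbon, a step of a number 10.6 percentage points higher from compound 1 to compound 3 (beyond the scatter). Compound 3 stands highest of the three numbers, beyond the scatter from compound 1 and from compound 2.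

Compound 4, `COc1ccc(-c2cc(C(C)=O)c3[nH]c(-c4ccc(OC)cc4)cc3c2)cc1`, has not yet been measured. It differs from compound 3 by methoxy in place of fluoro on an aromatic carbon, the same change as that between compound 1 and compound 2, at a place described in the same words. The step expected from compound 3 to compound 4 in this assay is a number 5 percentage points lower from compound 3 to compound 4 (within the scatter), set beside the earlier step, because the step of a number 5.6 percentage points lower from compound 1 to compound 2 (within the scatter) lay within the scatter and nothing in the three measured compounds points to a different outcome on the core of compound 3. Compound 4 is therefore estimated at 42%, with the likely range running from 28% to 56%.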

Compound 4, a percentage reported as activity, at one concentration (the size of the read-out at that concentration, not a potency): 39.9%
Compound 4: the middle estimate sits 2.1 percentage points above what was measured; the measured number falls inside the stated range.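

In this assay, methoxy in place of fluoro gave a number 7.1 percentage points lower from compound 3 to compound 4 (within the scatter), and this step on the second core does not differ from the earlier one: the same change on two cores in this assay, a number 5.6 percentage points lower (within the scatter) from compound 1 to compound 2 and a number 7.1 percentage points lower (within the scatter) from compound 3 to compound 4, 1.5 percentage points apart, within the scatter of two such steps. Methoxy in place of hydrogen gave a number 9.1 percentage points higher from compound 2 to compound 4 (within the scatter), and this step also agrees with its earlier counterpart: the same change on two cores in this assay, a number 10.6 percentage points higher (beyond the scatter) from compound 1 to compound 3 and a number 9.1 percentage points higher (within the scatter) from compound 2 to compound 4, 1.5 percentage points apart, within the scatter of two such steps. Both changes therefore carried over between these two cores, but each comparison rests on a single pair of steps at one concentration, the fluoro to methoxy steps themselves lie within the scatter, and nothing here shows that either change would behave the same way on any other core.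

The compounds shown leave open how the series would respond to other groups at these aromatic positions, such as an amine, a carboxylic acid or a longer alkoxy chain. On these data alone, all four compounds also carry the same acetyl group, so the effect of replacing it with, for example, a nitrile remains unknown.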